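A Fluorine Added to the Phenyl Ring

The source may report more compounds than this note shows. Statements on the series, on what has been measured and on what is new or still open speak of the compounds shown alone.

Of the compounds shown here, two built on a shared core have been measured in a physicochemical assay for lipophilicity; on this read-out lower numbers stand for lower lipophilicity and higher numbers for higher lipophilicity. Compound 1 `Nc1nn2c(O)cc(-c3cc([N+](=O)[O-])c(Cl)cc3Cl)nc2c1[N+](=O)[O-]` gives 2.77 in this assay. Compound 2 `Nc1nn2c(O)cc(-c3ccccc3)nc2c1[N+](=O)[O-]` gives 2.54 in this assay, the lower of the two numbers, though its gap to compound 1 lies within the usual scatter of such measurements, so the two cannot really be told apart. Compound 3 `Nc1nn2c(O)cc(-c3ccccc3F)nc2c1[N+](=O)[O-]` has not yet been measured. It differs from compound 2 in a single place: fluoro in place of hydrogen on an aromatic carbon of a six-membered aromatic ring of carbon only, ortho to a large group. Among the measured compounds shown here, no pair of measured compounds shows this same change, so its size can only be anticipated. The step is expected to be small and upward, a number 0.14 log units higher from compound 2 to compound 3 (within the scatter), and not clearly beyond the scatter. Compound 3 is estimated at 2.68, within a range from 2.45 to 2.95.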

Compound 3, partition coefficient: 2.34
Beside the measured number, compound 3's estimate is 0.34 log units above it; measured number below the stated range.
By their numbers in this assay, from the lowest: compounds 3, 2 and 1 (each within the scatter of the next, the first and the last beyond it).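

In this assay, the change from phenyl to 2-fluorophenyl comes to a number 0.20 log units lower from compound 2 to compound 3 (within the scatter). Among the compounds shown here, this is the first direct reading of fluoro in place of hydrogen on an aromatic carbon ortho to a large group, and at this place the change leaves compound 2 and compound 3 impossible to tell apart on this read-out. Nothing available bears on why the number came out as it did.

The compounds shown leave open whether a larger or differently built group on the same carbon, such as a methoxy group, an amine or a carboxylic acid, would produce a step beyond the scatter. They also leave open whether fluoro would give a similar reading on the phenyl ring of another compound, since this change appears only once.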